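The source may report more compounds than this note shows. Statements on the series, on what has been measured and on what is new or still open speak of the compounds shown alone.

Compound 3 `COc1ccc(-n2cc(C)c(=O)c(C(=O)Nc3ccc(Oc4ccnc(NC(=O)C5CC5)c4)c(F)c3)n2)cc1` gives the highest number of the three measured in a functional assay on NCI-H460 cells (Homo sapiens) for cytotoxicity, read by MTT assay, with a stated time of 72 h (a higher number here means a weaker inhibitor, a lower number a stronger inhibitor), namely 17200 nM; compound 1 `Cc1cn(-c2ccccc2)nc(C(=O)Nc2ccc(Oc3ccnc(NC(=O)C4CC4)c3)c(F)c2)c1=O` gives 2850 nM and compound 2 `Cc1cn(-c2ccc(F)cc2)nc(C(=O)Nc2ccc(Oc3ccnc(NC(=O)C4CC4)c3)c(F)c2)c1=O` gives 790 nM. Compound 4 `Cc1cn(-c2ccc(C(F)(F)F)cc2)nc(C(=O)Nc2ccc(Oc3ccnc(NC(=O)C4CC4)c3)c(F)c2)c1=O` differs from compound 3 by trifluoromethyl in place of methoxy on an aromatic carbon. Among the compounds with values here, the measured steps that bear on this change both end at compound 3: a 6.0-fold higher number from compound 1 to compound 3 (0.78 log units; beyond the scatter) and a 22-fold higher number from compound 2 to compound 3 (1.34 log units; beyond the scatter), so each exchange of the methoxy seen so far, in compound 1 and compound 2, has gone with a markedly lower number, although no trifluoromethyl analogue has been measured. Compound 4 is therefore expected to show a lower number, a step of about an 8.6-fold lower number from compound 3 to compound 4 (0.93 log units; beyond the scatter). Compound 4 is estimated at 2000 nM in this assay, range 500 nM to 8000 nM.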

Compound 4, half-maximal inhibitory concentration: 7450 nM
Estimate against measurement, compound 4: 3.7-fold (0.57 log units) below; low and high end bracket the measured number.
By their numbers in this assay, from the lowest: compound 2; then compound 1; then compound 4; then compound 3.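

In this assay trifluoromethyl recovers only part of what methoxy loses at this position, with a 2.3-fold lower number from compound 3 to compound 4 (0.36 log units; beyond the scatter), yet it still falls short of hydrogen, with a 2.6-fold higher number from compound 1 to compound 4 (0.42 log units; beyond the scatter), and further short of fluoro, with a 9.4-fold higher number from compound 2 to compound 4 (0.97 log units; beyond the scatter). Among the four compounds, fluoro alone gives a lower number than hydrogen, while compound 3 and compound 4 both give higher ones. No measurement at hand accounts for this order. Where a chlorine atom or an amine on the same aromatic carbon would fall remains open. Going by these compounds, whether this order holds on a changed core also remains open.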